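Dichlorophenyl in Place of Nitrophenyl on a Weak Series

This account rests on a few compounds, and the source may have more. Where it says the series, first, only, none or still open, it means among the compounds named here.

Two compounds of this series have been run in a functional assay on MIA PaCa-2 cells (Homo sapiens) for inhibition, read by MTT assay, with a stated time of 48 h, tested at 10 uM; a lower number here means less inhibition of growth, a higher number more inhibition of growth at the concentration tested. Compound 1, `CCOC(=O)N1CCN(Cc2c(O)c([C@H]3CCN(C)C[C@H]3O)c3oc(C)cc(=O)c3c2O)CC1`, gives 4% in this assay. Compound 2, `Cc1oc2c([C@H]3CCN(C)C[C@H]3O)c(O)cc(O)c2c(=O)c1C(O)c1ccc([N+](=O)[O-])cc1`, gives 2% in this assay; on the numbers as written it stands at the bottom of the two, but the gap to compound 1 lies within the scatter, so the two cannot be told apart. Compound 3, `Cc1oc2c([C@H]3CCN(C)C[C@H]3O)c(O)cc(O)c2c(=O)c1C(O)c1cccc(Cl)c1Cl`, has not yet been measured. It differs from compound 2 by 2,3-dichlorophenyl in place of 4-nitrophenyl on a saturated chain carbon bound to an aromatic carbon and an oxygen on a saturated carbon. Within the data shown here, no step between measured compounds is available to gauge this change, and both numbers known so far sit near the floor of the scale. Compound 3 is therefore expected to show a step of a number 3 percentage points higher from compound 2 to compound 3 (within the scatter) from compound 2, meaning none beyond the scatter. The estimate for compound 3 in this assay is 5%, expected to fall between -5% and 20%.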

Compound 3, percent growth inhibition at one concentration: 2%
Estimate against measurement, compound 3: 3 percentage points above, and the stated range covers the measured number.
By their numbers in this assay, from the lowest: compounds 2, 3 and 1 (each within the scatter of the next).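

The exchange of 4-nitrophenyl for 2,3-dichlorophenyl on the saturated chain carbon gives this series its first readable step in this assay and that step reads no change at the digits printed from compound 2 to compound 3 (within the scatter) at this position. Two aryl groups that share one six-membered aromatic ring but carry different substituents, nitro on one and two chlorines on the other, therefore cannot be told apart here, and neither compound 2 nor compound 3 rises clear of the scatter. No measurement shown bears on why the reading stays put.

Going by these compounds, what remains open is whether this position responds to anything at all, for instance a piperidine or a carboxylic acid on the saturated chain carbon in place of the aromatic ring. A single pair also cannot show whether any other place on the shared core matters more.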